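The compounds below may be only part of what the source reports. "The series", "measured", "known", "first", "only" and "open" are said of these compounds alone.

In a physicochemical assay for lipophilicity, measured as octanol-water partition (a lower number here means a more polar compound, a higher number a more lipophilic compound), the two measured compounds stand as follows:

Compound 1 `COc1cc(NC(C)CCCN2C(=O)CN(C(=O)[C@@H](C)N)C2(C)C)c2ncccc2c1` — 2.49
Compound 2 `COc1cc(NC(C)CCCN2C(=O)[C@@H](C)NC2(C)C)c2ncccc2c1` — 3.25

Compound 1 holds the lower of the two numbers in this assay; compound 2 sits higher, and the gap between the two values lies beyond the usual scatter of the measurement. Within the data shown here, no single-point step connects them, so their two values are all that can be said of that pair.

The compound not yet measured is compound 3 `CC[C@H](C)[C@@H](N)C(=O)N1CC(=O)N(CCCC(C)Nc2cc(OC)cc3cccnc23)C1(C)C`. It differs from compound 1 in one place: sec-butyl in place of methyl on a saturated chain carbon bound to an amine nitrogen and a carbonyl carbon. For compound 3 the partition coefficient is expected to move upward from the value of compound 1, by a step clearly beyond the scatter. The expected step is estimated as a number 1.11 log units higher from compound 1 to compound 3 (beyond the scatter). Compound 3 is expected to come in at about 3.6, within a range from 3 to 4.2.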

Compound 3, partition coefficient: 3.4
Compound 3: the middle estimate sits 0.20 log units above what was measured; the range from low to high includes it.
By their numbers in this assay, from the lowest: compound 1; then compounds 2 and 3 (each within the scatter of the next).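

In this assay, among these compounds, sec-butyl in place of methyl on a saturated chain carbon bound to an amine nitrogen and a carbonyl carbon gives a number 0.91 log units higher from compound 1 to compound 3 (beyond the scatter) as the only single-place step in this set. It shows that the partition coefficient responds to a change at this position, even though the swap from 1 heavy atom to 4 heavy atoms adds no hydrogen-bond donor or acceptor and no ring. Nothing available accounts for the size of this step.

From the compounds shown here alone, whether intermediate groups such as ethyl or isopropyl would give smaller steps remains open, as does whether a straight butyl chain would match sec-butyl. Going by these compounds, it is also open how a hydroxyl or a carboxylic acid at this position would shift the number, and whether the other arrangement of the sec-butyl stereocentre would read the same.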